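The compounds below may be only part of what the source reports. "The series", "measured", "known", "first", "only" and "open" are said of these compounds alone.

Measured compounds in a functional assay on RXF 393 cells (Homo sapiens) for inhibition, read by sulforhodamine B assay, with a stated time of 48 h; on this read-out higher numbers stand for weaker inhibition of growth and lower numbers for stronger inhibition of growth:

compound 1 `COc1ccc(-c2cc(/C=C/C(=O)c3ccc(N)cc3)[nH]n2)cc1`: 1670 nM
compound 2 `COc1cc(-c2cc(/C=C/C(=O)c3ccc(N)cc3)[nH]n2)cc(OC)c1OC`: 1350 nM
compound 3 `COc1cc(-c2cc(/C=C/C(=O)c3ccc(F)c(F)c3)[nH]n2)cc(OC)c1OC`: 2050 nM

Compound 2 gives the lowest number of the three, but its distance to compound 1 and to compound 3 is within the scatter, so no order among the three can be read from these values. Among the measured compounds shown here, the only single-point step measured is a 1.5-fold higher number from compound 2 to compound 3 (0.18 log units; within the scatter), and it is within the scatter.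

Compound 4 `COc1ccc(-c2cc(/C=C/C(=O)c3ccc(N)cc3)[nH]n2)cc1OC` has not yet been measured. It differs from compound 2 by hydrogen in place of methoxy on an aromatic carbon. For the measured compounds named here, no measured step covers this change: compound 1 and compound 2 differ in more than one place, and the step from compound 2 to compound 3 alters a different part of the molecule. What the data show is that the three measured numbers, including compound 1 with fewer methoxy groups on that ring, all sit within the scatter of one another.

On that basis, no step beyond the scatter is expected in this assay from compound 2 to compound 4. The estimate for compound 4 is 1500 nM, with a range of 700 nM to 3200 nM. This estimate corresponds to an expected step of a 1.1-fold higher number from compound 2 to compound 4 (0.05 log units; within the scatter).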

Compound 4, concentration for 50% growth inhibition: 2150 nM
Compound 4: middle estimate off by 1.4-fold (0.16 log units), on the low side; the range from low to high includes it.
By their numbers in this assay, from the lowest: compounds 2, 1, 3 and 4 (each within the scatter of the next).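

With hydrogen in place of methoxy on the aromatic carbon ortho to a methoxy group and meta to a large group, this assay gives a 1.6-fold higher number from compound 2 to compound 4 (0.20 log units; within the scatter), and methoxy in place of hydrogen on an aromatic carbon of the same ring gives a 1.3-fold higher number from compound 1 to compound 4 (0.11 log units; within the scatter). Single-place methoxy changes on this ring can now be read with the 4-aminophenyl side held constant, which compound 1 and compound 2 alone did not allow, as they differ in more than one place; neither step lies beyond the scatter. No measurement here offers an explanation for these numbers.

Open, from the compounds shown here alone, is whether a hydroxyl group, a chlorine atom or an amine on this carbon would stay within the scatter of compound 2. Also open, going by these compounds, is what hydrogen in place of every methoxy group on this ring would give.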